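This account rests on a few compounds, and the source may have more. Where it says the series, first, only, none or still open, it means among the compounds named here.

Measured in a functional assay on SK-BR-3 cells (Homo sapiens) for antiproliferative activity, read by MTT assay, with a stated time of 72 h; on this read-out lower numbers stand for stronger inhibition and higher numbers for weaker inhibition:

- compound 1 `C#CCOC(=O)C[C@@H]1C(C(=O)OC)=CO[C@@H](O[C@@H]2O[C@H](CO)[C@@H](O)[C@H](O)[C@H]2O)/C1=C/C` — a limit of the assay, > 15000 nM
- compound 2 `C/C=C1/[C@H](O[C@@H]2O[C@H](CO)[C@@H](O)[C@H](O)[C@H]2O)OC=C(C(=O)OC)[C@H]1CC(=O)OCc1ccccc1` — again only a limit, > 15000 nM
- compound 3 `C/C=C1/[C@H](O[C@@H]2O[C@H](CO)[C@@H](O)[C@H](O)[C@H]2O)OC=C(C(=O)OC)[C@H]1CC(=O)OCCC(C)C` — 9020 nM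

Within the data shown here, compound 3 thus carries the only true number in this set; the other two sit at the limit of > 15000 nM in this assay, at which 2 of the 3 values shown sit, and give no number at all. The measured steps that end at compound 3 both point the same way: an at least 1.6-fold lower number from compound 1 to compound 3 (0.22 log units; that floor lies within the scatter) and an at least 1.6-fold lower number from compound 2 to compound 3 (0.22 log units; that floor lies within the scatter), while a step that the two limits leave unreadable from compound 1 to compound 2. So replacing ethynyl or phenyl with isobutyl at the ester carbon is the one move that brought a readable value.

Compound 4 `C/C=C1/[C@H](O[C@@H]2O[C@H](CO)[C@@H](O)[C@H](O)[C@H]2O)OC=C(C(=O)OC)[C@H]1CC(=O)OCCc1ccc([N+](=O)[O-])cc1` reverses that move in spirit: 4-nitrophenyl in place of isopropyl on a saturated chain carbon, two bonds along the chain from an oxygen next to a carbonyl group. The closest measured precedent is the step from phenyl to isobutyl, which lowered the number to compound 3; putting an aromatic ring back onto the ester chain is expected to undo that gain, so a weaker value is anticipated, a 1.7-fold higher number from compound 3 to compound 4 (0.22 log units; within the scatter). The estimate for compound 4 is therefore 15000 nM, with a plausible range from 6000 nM to 30000 nM, and a real chance that the assay again reports only a limit.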

Compound 4, half-maximal inhibitory concentration: > 20000 nM
Compound 4 ended at the assay's limit (the forecaster's own chance of this, stated with the estimate: 55%); middle value at least 1.3-fold (0.12 log units) from the limit.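

Among these compounds, compound 4 gives only a limit of the assay in this assay: the limit of > 20000 nM in this assay, at which 1 of the 4 values shown sits. Even so, that limit still allows a size to be read, and this is the first step at this position to clear the usual scatter: an at least 2.2-fold higher number from compound 3 to compound 4 (0.34 log units; beyond the scatter). The isopentyl ester of compound 3 therefore stands apart from the 2-(4-nitrophenyl)ethyl ester of compound 4 beyond the usual scatter. An aromatic ring on the chain is not the only structure found at a limit, as compound 1 carries ethynyl and no ring.

The steps from compound 1 and from compound 2 to compound 4 join two limits and cannot be read, so these three compounds cannot be put in order. As far as these compounds go, it also stays open whether the difference between compound 3 and compound 4 follows the ring or the nitro group, a question that a plain 2-phenylethyl ester could address, while a longer alkyl chain would show whether the isopentyl ester can be improved on.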